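From 2-fluorophenyl to 3-aminophenyl on the shared core

This account rests on a few compounds, and the source may have more. Where it says the series, first, only, none or still open, it means among the compounds named here.

Among the measured compounds shown here, in a functional assay on MCF7 cells (Homo sapiens) for cytotoxicity, read by MTT assay, with a stated time of 96 h (on this read-out higher numbers stand for weaker inhibition and lower numbers for stronger inhibition), the three compounds measured so far read as follows.

compound 1 `COc1cccc(-n2cc(C(=O)c3cc(OC)c(OC)c(OC)c3)c(-c3ccccc3)c2)c1` gives 500 nM
compound 2 `COc1cc(C(=O)c2cn(-c3ccccc3)cc2-c2cccc(Cl)c2)cc(OC)c1OC` gives 540 nM
compound 3 `COc1cc(C(=O)c2cn(-c3cccc(C)c3)cc2-c2ccccc2F)cc(OC)c1OC` gives 190 nM

Compound 3 has the lowest number of the three, and its gaps to compound 1 and to compound 2 both lie beyond the usual scatter. Compound 1 and compound 2 lie within the scatter of each other.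

Compound 4 `COc1cc(C(=O)c2cn(-c3cccc(C)c3)cc2-c2cccc(N)c2)cc(OC)c1OC` has yet to be measured in this assay and keeps the 3-methylphenyl group of compound 3. On an aromatic carbon of the five-membered aromatic ring with 1 nitrogen, 3-aminophenyl stands in place of 2-fluorophenyl (3-aminophenyl in place of 2-fluorophenyl on an aromatic carbon). For the measured compounds named here, none of the measured compounds carries 3-aminophenyl, and no two of them differ in one place only. The data therefore give no direct size for this change, and any expectation is loose. It starts from compound 3 at 190 nM and leans towards stronger inhibition. The estimated change is a 2.4-fold lower number from compound 3 to compound 4 (0.38 log units; beyond the scatter), although a much smaller step would also fit these data. For compound 4 the estimated value is 80 nM, with an expected range from 15 nM to 400 nM, and the measurement will settle it.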

Compound 4, half-maximal inhibitory concentration: 130 nM
Estimate against measurement, compound 4: 1.6-fold (0.21 log units) below; low and high end bracket the measured number.
By their numbers in this assay, from the lowest: compounds 4 and 3 (each within the scatter of the next); then compounds 1 and 2 (each within the scatter of the next).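

Among the compounds shown here, this gives the first direct reading at this position: in this assay the exchange of 2-fluorophenyl for 3-aminophenyl gives a 1.5-fold lower number from compound 3 to compound 4 (0.16 log units; within the scatter) and so leaves the two compounds indistinguishable on this read-out. With the 3-methylphenyl group held constant, this aromatic carbon of the shared core therefore takes either group without a difference that stands out from the scatter, even though only 3-aminophenyl counts a hydrogen-bond donor and acceptor. Nothing available here accounts for the two groups reading alike.

From the compounds shown here alone, it remains open how a 3-hydroxyphenyl or 3-acetamidophenyl group would read at this position with the 3-methylphenyl group kept, and so whether the amine itself has any bearing on the number. Going by these compounds, it is also open whether the same exchange would read alike when the group on the ring nitrogen is the unsubstituted phenyl of compound 2 or the 3-methoxyphenyl of compound 1.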